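Swapping fluoro for trifluoromethyl on compound 3

This account rests on a few compounds, and the source may have more. Where it says the series, first, only, none or still open, it means among the compounds named here.

Compound 1 `c1ccc(-c2ccc(-c3ccc(-c4nc5ccccc5[nH]4)cc3)cc2)cc1` gives 41200 nM
Compound 2 `Cc1ccc2[nH]c(-c3ccc(-c4ccc(-c5ccc(N(C)C)cc5)cc4)cc3)nc2c1` gives 3510 nM
Compound 3 `Fc1ccc(-c2ccc(-c3ccc(-c4nc5ccccc5[nH]4)cc3)cc2)cc1` gives 33200 nM

In a functional assay on A549 cells (Homo sapiens) for inhibition, read by sulforhodamine B assay (on this read-out higher numbers stand for weaker inhibition of growth and lower numbers for stronger inhibition of growth), compound 3 sits within the scatter of compound 1, while compound 2 has a clearly lower number, beyond the scatter. So compound 3 stands with the weaker pair of these three.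

Compound 4 `FC(F)(F)c1ccc(-c2ccc(-c3ccc(-c4nc5ccccc5[nH]4)cc3)cc2)cc1` has not yet been measured. It carries trifluoromethyl in place of fluoro on an aromatic carbon, para to a large group, so 4-fluorophenyl becomes 4-(trifluoromethyl)phenyl (trifluoromethyl in place of fluoro on an aromatic carbon).

For the measured compounds named here, only one measured step bears on this change. It put fluoro in place of hydrogen on an aromatic carbon, and it was small (a 1.2-fold lower number from compound 1 to compound 3 (0.09 log units; within the scatter)), so no step beyond the scatter is expected for compound 4 in this assay. Compound 2 differs from compound 3 in more than one place and offers no clean comparison. Going by the values given here, a single step is thin evidence, and no measured compound yet carries trifluoromethyl, so the range is kept wide.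

The expected change is small (a 1.1-fold lower number from compound 3 to compound 4 (0.04 log units; within the scatter)) and lies within the scatter. The estimate for compound 4 is 30000 nM with an expected range from 12000 nM to 75000 nM at its ends.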

Compound 4, concentration for 50% growth inhibition: 36600 nM
Estimate against measurement, compound 4: 1.2-fold (0.09 log units) below; measured number inside the range.
By their numbers in this assay, from the lowest: compound 2; then compounds 3, 4 and 1 (each within the scatter of the next).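

In this assay, trifluoromethyl brings 4 heavy atoms where fluoro has 1, yet this larger group gives a 1.1-fold higher number from compound 3 to compound 4 (0.04 log units; within the scatter), and measured against plain hydrogen on the same carbon it gives a 1.1-fold lower number from compound 1 to compound 4 (0.05 log units; within the scatter). The earlier step from hydrogen to fluoro swapped one atom for another, so it could not show what happens when a group of several atoms sits at this spot. Now three groups of different size on this aromatic carbon, para to a large group, are all within the scatter of one another, so in compounds 1, 3 and 4 the read-out does not separate hydrogen, fluoro and trifluoromethyl.

On these data alone, all three of these groups lack hydrogen-bond donors and acceptors, so it remains open whether a group that differs in kind, such as a carboxylic acid, a hydroxyl or a longer chain, would move the number at this position. What lies behind this flat result also stays open, as no measurement of any property of these compounds stands beside the growth data to explain it.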